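The source may report more compounds than this note shows. Statements on the series, on what has been measured and on what is new or still open speak of the compounds shown alone.

Notes on the series in an ADME assay on L02 cells (Homo sapiens) for cytotoxicity, read by MTT assay; on this read-out lower numbers stand for stronger inhibition and higher numbers for weaker inhibition. Compound 1 `CCC(=O)Oc1cc(/C=C/C(=O)c2ccc(OC)c3c2OC(C)(C)C=C3)ccc1OC` reads > 10000 nM, a limit and not a number. Compound 2 `C=CC(=O)Oc1cc(/C=C/C(=O)c2ccc(OC)c3c2OC(C)(C)C=C3)ccc1OC` reads > 10000 nM, also a limit, so it has no exact position; (the limit of > 10000 nM in this assay, at which 2 of the 2 values shown sit). Within the data shown here, the one measured step is a step that the two limits leave unreadable from compound 1 to compound 2, and it gives no size to carry forward. Compound 3 `COc1ccc(/C=C/C(=O)Oc2cc(/C=C/C(=O)c3ccc(OC)c4c3OC(C)(C)C=C4)ccc2OC)cc1` differs from compound 2 by 2-(4-methoxyphenyl)ethenyl in place of vinyl on a carbonyl carbon. Among the measured compounds shown here, with no sized step behind it, no clear shift in either direction is expected, and the expected step is a step that the limit leaves unreadable from compound 2 to compound 3. Compound 3 is estimated at 20000 nM, with an expected range of 8000 nM to 50000 nM.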

Compound 3, half-maximal inhibitory concentration: 18000 nM
Beside the measured number, compound 3's estimate is 1.1-fold (0.05 log units) above it; measured number inside the range.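

No new step can be read from compound 1 to compound 3 or from compound 2 to compound 3, because compound 1 and compound 2 are limits: the limit of > 10000 nM in this assay, at which 2 of the 3 values shown sit.

On these data alone, whether 2-(4-methoxyphenyl)ethenyl shifts this assay relative to vinyl or ethyl stays open.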